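Cinnamanilide series: amino added to the methoxyphenyl ring

This account rests on a few compounds, and the source may have more. Where it says the series, first, only, none or still open, it means among the compounds named here.

Measured so far:
compound 1 `COc1cccc(/C=C/C(=O)Nc2cc(OC)c(OC)c(OC)c2)c1` gives 12300 nM in a functional assay on HeLa cells (Homo sapiens) for cytotoxicity, read by MTT assay, with a stated time of 72 h; on this read-out higher numbers stand for weaker inhibition and lower numbers for stronger inhibition
compound 2 `COc1ccc(/C=C/C(=O)Nc2cc(C(=O)c3cc(OC)c(OC)c(OC)c3)ccc2OC)cc1` gives 10700 nM in this assay
compound 3 `COc1ccc(/C=C/C(=O)Nc2cc(C(=O)c3cc(OC)c(OC)c(OC)c3)cc(OC)c2OC)cc1` gives 11200 nM in this assay

Compound 3 sits within the scatter of both other compounds: its gap to compound 2 and its gap to compound 1 are both inside the usual spread of repeated measurements, so the three numbers cannot be told apart. Among the measured compounds shown here, the only step between compounds differing in one place, a 1.0-fold higher number from compound 2 to compound 3 (0.02 log units; within the scatter), changed nothing beyond the scatter.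

Compound 4 `COc1ccc(/C=C/C(=O)Nc2cc(C(=O)c3cc(OC)c(OC)c(OC)c3)cc(OC)c2OC)cc1N` is the next compound. Relative to compound 3 the change is amino in place of hydrogen on an aromatic carbon. For the measured compounds named here, no measured step touches this ring or this group; the one step in hand, a 1.0-fold higher number from compound 2 to compound 3 (0.02 log units; within the scatter), concerns a different ring and was flat, and all three measured compounds cluster in the same band of this assay. There is therefore no basis in the data for expecting movement in either direction, and the step of a 1.0-fold lower number from compound 3 to compound 4 (0.01 log units; within the scatter) is expected to stay within the scatter. Compound 4 is estimated at 11000 nM in this assay, with a range from 4000 nM to 30000 nM.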

Compound 4, half-maximal inhibitory concentration: 15800 nM
The estimate for compound 4 lay 1.4-fold (0.16 log units) below the measured number; the measured number falls inside the stated range.
By their numbers in this assay, from the lowest: compounds 2, 3, 1 and 4 (each within the scatter of the next).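

In this assay the first change shown on this ring, 4-methoxyphenyl to 3-amino-4-methoxyphenyl, gives a 1.4-fold higher number from compound 3 to compound 4 (0.15 log units; within the scatter) and so does not separate from the scatter. Among the compounds shown here, an amino group on this aromatic carbon, ortho to a methoxy group and meta to a large group, therefore leaves the read-out in the same band as the parent, which the earlier compounds could not show for this ring. With the step of a 1.0-fold higher number from compound 2 to compound 3 (0.02 log units; within the scatter) on the other side of the molecule also flat, neither single change shown so far gives a readable effect, and no measured information is available to interpret the amino step further.

Still open, going by these compounds, is whether a hydroxy, a dimethylamino or an acetamido group at this same place would read differently, or whether an amino group on another carbon of this ring would behave as it does here. Also open, on these data alone, is whether the amino group reads the same on compound 2, which lacks the extra methoxy group of compound 3, and whether any change on this ring can move the number beyond the scatter.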